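Terminal aryl substituent changes on a shared core

The source may report more compounds than this note shows. Statements on the series, on what has been measured and on what is new or still open speak of the compounds shown alone.

Measured compounds:
compound 1, `COc1ccc(/C=N/NC(=O)Nc2ccc(Oc3ccnc4cc(OCCCN5CCCCC5)c(OC)cc34)c(F)c2)cc1`, gives 840 nM in a functional assay on MDA-MB-231 cells (Homo sapiens) for cytotoxicity, read by MTT assay, with a stated time of 72 h; a lower number here means a stronger inhibitor, a higher number a weaker inhibitor
compound 2, `COc1cc2c(Oc3ccc(NC(=O)N/N=C/c4ccc(C(F)(F)F)cc4)cc3F)ccnc2cc1OCCCN1CCCCC1`, gives 1100 nM in this assay
compound 3, `COc1cc2c(Oc3ccc(NC(=O)N/N=C/c4ccc(Cl)cc4Cl)cc3F)ccnc2cc1OCCCN1CCCCC1`, gives 750 nM in this assay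

Compound 2 stands at the highest of the three numbers, yet a 1.3-fold higher number from compound 1 to compound 2 (0.12 log units; within the scatter) and a 1.5-fold lower number from compound 2 to compound 3 (0.17 log units; within the scatter) both lie within the scatter, as does a 1.1-fold lower number from compound 1 to compound 3 (0.05 log units; within the scatter). The three measured compounds therefore give no usable signal from the group on the terminal aryl ring.

Compound 4, `COc1cc2c(Oc3ccc(NC(=O)N/N=C/c4ccc(O)cc4)cc3F)ccnc2cc1OCCCN1CCCCC1`, differs from compound 2 by hydroxy in place of trifluoromethyl on an aromatic carbon. Going by the values given here, the steps that bear on this are the exchanges at the same aryl position: methoxy to trifluoromethyl, trifluoromethyl to 2,4-dichlorophenyl and methoxy to 2,4-dichlorophenyl, each of them within the scatter. On that basis no step beyond the scatter is expected in this assay for hydroxy in place of trifluoromethyl; the estimate for a 1.2-fold lower number from compound 2 to compound 4 (0.09 log units; within the scatter) is accordingly set close to nil.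

Compound 4 is expected to give about 900 nM, with a range from 400 nM to 2000 nM.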

Compound 4, half-maximal inhibitory concentration: 790 nM
For compound 4 the middle estimate is 1.1-fold (0.06 log units) above the measured one, within the range that was stated.
By their numbers in this assay, from the lowest: compounds 3, 4, 1 and 2 (each within the scatter of the next).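

In this assay, the exchange of 4-(trifluoromethyl)phenyl for 4-hydroxyphenyl gives a 1.4-fold lower number from compound 2 to compound 4 (0.14 log units; within the scatter), so a hydrogen-bond donor and a hydrogen-bond acceptor enter at this position, where trifluoromethyl has neither, without a step beyond the scatter. Replacing the methyl on the oxygen with hydrogen gives a 1.1-fold lower number from compound 1 to compound 4 (0.03 log units; within the scatter), and 4-hydroxyphenyl in place of 2,4-dichlorophenyl gives a 1.1-fold higher number from compound 3 to compound 4 (0.02 log units; within the scatter), so all four terminal aryl groups now read alike within the scatter. No measurement is available to account for this flat response.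

As far as these compounds go, whether an amine or a carboxylic acid on the same aromatic carbon would produce a step beyond the scatter remains open. So does whether a longer chain on the oxygen of compound 4 would do so.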